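The source may report more compounds than this note shows. Statements on the series, on what has been measured and on what is new or still open speak of the compounds shown alone.

Measured so far:
- compound 1, `Cn1c(=O)c(S(=O)(=O)c2ccc(F)cc2F)cc2cnc(Nc3cccc4[nH]ccc34)nc21`: 750 nM
- compound 2, `Cn1c(=O)c(S(=O)(=O)c2ccc(F)cc2F)cc2cnc(Nc3cnc4[nH]ccc4c3)nc21`: 750 nM
- compound 3, `Cn1c(=O)c(S(=O)(=O)c2ccc(Cl)cc2)cc2cnc(Nc3cccc4[nH]ccc34)nc21`: 5000 nM

All three were tested in a functional assay on DU-145 cells (Homo sapiens) for inhibition, read by trypan blue exclusion, with a stated time of 72 h; a higher number here means a weaker inhibitor, a lower number a stronger inhibitor. Compound 1 and compound 2 share the same core and differ only in the group attached to a nitrogen on an aromatic ring: a group of 9 heavy atoms (7 carbon, 2 nitrogen; one five-membered aromatic ring with 1 hetero atom, one six-membered aromatic ring with 1 hetero atom) in place of a group of 9 heavy atoms (8 carbon, 1 nitrogen; one five-membered aromatic ring with 1 hetero atom, one six-membered aromatic ring of carbon only), on a nitrogen on an aromatic ring. That swap made no change at the digits printed from compound 1 to compound 2 (within the scatter), so the two readings are indistinguishable here. Compound 3 keeps the group of compound 1 on that nitrogen but carries a different ring on the sulfonyl sulfur: 4-chlorophenyl in place of 2,4-difluorophenyl on a sulfonyl sulfur. That change made a 6.7-fold higher number from compound 1 to compound 3 (0.82 log units; beyond the scatter), a step large enough to count.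

Compound 4, `Cn1c(=O)c(S(=O)(=O)c2ccc(Cl)cc2)cc2cnc(Nc3cnc4[nH]ccc4c3)nc21`, has not yet been measured. It stands to compound 3 exactly as compound 2 stands to compound 1: a group of 9 heavy atoms (7 carbon, 2 nitrogen; one five-membered aromatic ring with 1 hetero atom, one six-membered aromatic ring with 1 hetero atom) in place of a group of 9 heavy atoms (8 carbon, 1 nitrogen; one five-membered aromatic ring with 1 hetero atom, one six-membered aromatic ring of carbon only), on a nitrogen on an aromatic ring. The place of the change is described in the same words in both pairs, so this is the same change, made on a core that differs from the core of compound 1 only by 4-chlorophenyl in place of 2,4-difluorophenyl on a sulfonyl sulfur.

Since the identical swap from compound 1 to compound 2 produced no change at the digits printed from compound 1 to compound 2 (within the scatter), the step from compound 3 to compound 4 in this assay is expected to be similarly small, no change at the digits printed from compound 3 to compound 4 (within the scatter). For the measured compounds named here, compound 4 is therefore estimated at 5000 nM, most likely somewhere between 2000 nM and 12000 nM, resting on the single earlier instance of this change.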

Compound 4, half-maximal inhibitory concentration: 5000 nM
Beside the measured number, compound 4's estimate shows no gap at the digits printed; the measured number falls inside the stated range.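

In this assay, placing the group whose six-membered aromatic ring holds a nitrogen in the position of 1H-indol-4-yl, on a nitrogen on an aromatic ring, gave no change at the digits printed from compound 3 to compound 4 (within the scatter), the same outcome as on the core of compound 1: the same change on two cores in this assay, no change at the digits printed (within the scatter) from compound 1 to compound 2 and no change at the digits printed (within the scatter) from compound 3 to compound 4, 1.0-fold (0.00 log units) apart, within the scatter of two such steps The other change, 4-chlorophenyl in place of 2,4-difluorophenyl on a sulfonyl sulfur, gave a 6.7-fold higher number from compound 2 to compound 4 (0.82 log units; beyond the scatter), and it also kept its size on moving to a second core: the same change on two cores in this assay, a 6.7-fold higher number (0.82 log units; beyond the scatter) from compound 1 to compound 3 and a 6.7-fold higher number (0.82 log units; beyond the scatter) from compound 2 to compound 4, 1.0-fold (0.00 log units) apart, within the scatter of two such steps Within these four compounds, then, each change had the same effect whichever group stood at the other place, but this rests on just two cores per change and a single cell assay, so it does not show that the effects would add up this neatly for other groups or in other assays.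

The sulfonyl step alters the halogens and their number at once, so the compounds shown cannot say which part of it matters; 4-fluorophenyl, 2-fluorophenyl or plain phenyl on the sulfonyl sulfur would help to separate these. As far as these compounds go, it also remains open how far the pattern would hold if a group carrying an amine or a carboxylic acid stood on the aromatic ring attached to that nitrogen.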